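Swapping the Aryl on the Core: Compound 3 to Compound 4

The compounds below may be only part of what the source reports. "The series", "measured", "known", "first", "only" and "open" are said of these compounds alone.

Compound 1, `O=C(O)Cc1sc(CSc2ccccc2)nc1-c1ccc(Cl)cc1`, gives 450 nM.
Compound 2, `O=C(O)Cc1sc(C(c2ccccc2)c2ccc(F)cc2)nc1-c1ccc(Cl)cc1`, gives 36 nM.
Compound 3, `O=C(O)Cc1sc(C(c2ccc(F)cc2)c2ccc(F)cc2)nc1-c1ccc(Cl)cc1`, gives 180 nM.

These three values come from an in vitro functional assay on HEK285-7 cells for antagonist activity at prostaglandin D2 receptor 2 (Homo sapiens), read by BRET and beta-arrestin recruitment; a higher number here means a weaker inhibitor, a lower number a stronger inhibitor. Among them compound 3 stands second highest: its nearest neighbour is compound 1, whose number is higher, and compound 2 lies furthest from it with a lower number. Within the data shown here, the only step between measured compounds that differ in one place is a 5.0-fold higher number from compound 2 to compound 3 (0.70 log units; beyond the scatter), a modest one, and it concerns the group on the other side of the shared core.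

Compound 4, `O=C(O)Cc1sc(C(c2ccc(F)cc2)c2ccc(F)cc2)nc1-c1cccc(F)c1`, differs from compound 3 in a single way: 3-fluorophenyl in place of 4-chlorophenyl on an aromatic carbon. Among the measured compounds shown here, no measured step touches this position on the core, so the measured steps give no direct guide to the size or direction of this change. On the numbers shown alone, compound 4 is expected to give about 400 nM in this assay, with a range from 150 nM to 1200 nM. This estimate corresponds to an expected step of a 2.2-fold higher number from compound 3 to compound 4 (0.35 log units; beyond the scatter), which may or may not exceed the scatter.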

Compound 4, half-maximal inhibitory concentration: 18 nM
Estimate against measurement, compound 4: 22-fold (1.35 log units) above; measured number outside the range, below it.
By their numbers in this assay, from the lowest: compounds 4 and 2 (each within the scatter of the next); then compound 3; then compound 1.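

The position on the aromatic carbon next to the ring nitrogen proves sensitive: 3-fluorophenyl in place of 4-chlorophenyl gives a 10-fold lower number from compound 3 to compound 4 (1.00 log units; beyond the scatter). The earlier compounds shown here all carry 4-chlorophenyl here, whereas compound 4 shows that this group is not required for a low number and that a swap leaving the counts of heavy atoms, hydrogen-bond donors and acceptors unchanged can still move the number beyond the scatter. No available evidence bears on what lies behind this step.

The change alters both the halogen and its place on the phenyl ring, and the compounds shown cannot separate the two: 3-chlorophenyl and 4-fluorophenyl would be needed for that. Also open, on these data alone, are what plain phenyl would give here and whether 3-fluorophenyl would act alike alongside the other group of compound 2.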